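A few compounds are considered here, and "the series" means these few. Any claim that something is new, unique, unknown or untested is made for them only; others in the source may bear on it.

Of the compounds shown here, three have so far been measured in a functional assay on A-375 cells (Homo sapiens) for activation, with a stated time of 3 days; a higher number here means that more compound is needed for the effect, a lower number that less compound is needed. Compound 1 `O=C(Nc1ccc(-c2cscn2)cc1)C1CCCN(Cc2ccc(F)c(F)c2)C1` gives 1240 nM. Compound 2 `O=C(Nc1ccc(-c2cscn2)cc1)C1CCCN(Cc2cc(F)c(F)c(F)c2)C1` differs from compound 1 by fluoro in place of hydrogen on an aromatic carbon, and in this assay compound 2 gives 1260 nM. That step is a 1.0-fold higher number from compound 1 to compound 2 (0.01 log units; within the scatter), so the two numbers cannot be told apart. Compound 3 `O=C(Nc1ccc(-c2ccc[nH]2)cc1)[C@H]1CCCN(Cc2ccc(F)c(F)c2)C1` carries a different core; how its core differs from that of compound 1 is not broken down here. In this assay compound 3 gives 140 nM, the lowest number of the three, and the gaps from compound 3 to compound 1 and to compound 2 both lie beyond the scatter.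

Compound 4 `O=C(Nc1ccc(-c2ccc[nH]2)cc1F)[C@H]1CCCN(Cc2ccc(F)c(F)c2)C1` has not yet been measured. It differs from compound 3 by fluoro in place of hydrogen on an aromatic carbon. For the measured compounds named here, this is the same kind of change as the one from compound 1 to compound 2, but not the same: there the entering fluoro stood ortho to a fluoro group, meta to a fluoro group and meta to a large group, whereas here it stands ortho to a large group and meta to a 1H-pyrrol-2-yl group. The step expected from compound 3 to compound 4 is a 1.3-fold higher number from compound 3 to compound 4 (0.11 log units; within the scatter), which rests on the earlier step of the same kind having stayed within the scatter, while the different surroundings leave room for a somewhat larger move in either direction. The estimate for compound 4 is 180 nM, with a range from 70 nM to 500 nM.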

Compound 4, half-maximal effective concentration: 100 nM
Beside the measured number, compound 4's estimate is 1.8-fold (0.26 log units) above it; the range from low to high includes it.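

In this assay, putting fluoro in place of hydrogen on the six-membered aromatic ring of the newer core gives a 1.4-fold lower number from compound 3 to compound 4 (0.15 log units; within the scatter), so the two numbers cannot be told apart. Set beside the earlier case, the same kind of change shows no difference between the two cores: the same change on two cores in this assay, a 1.0-fold higher number (0.01 log units; within the scatter) from compound 1 to compound 2 and a 1.4-fold lower number (0.15 log units; within the scatter) from compound 3 to compound 4, 1.4-fold (0.15 log units) apart, within the scatter of two such steps. For the compounds shown here, this shows that, in these two pairs, adding one fluoro left the number within the scatter on both cores, but it does not show that the change would do so on every core, since there are only two pairs, the fluoro enters at a different place in each, and a small real effect could hide inside the scatter.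

The compounds shown leave open whether a larger group in the same place, such as chloro, methyl or methoxy, would move the number beyond the scatter, since fluoro is the only group that replaces this hydrogen here. They also leave open whether fluoro at the other free carbons of that ring, or at this same place on the core of compound 1, would behave as it does in compound 4.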